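The source may report more compounds than this note shows. Statements on the series, on what has been measured and on what is new or still open speak of the compounds shown alone.

In a functional assay on MDA-MB-231 cells (Homo sapiens) for inhibition, read by MTT assay, with a stated time of 48 h (a lower number here means a stronger inhibitor, a higher number a weaker inhibitor), compound 1 `CN1C(=O)CN(C2CCCC2)c2nc(Nc3ccc(N4CCCCC4)cn3)ncc21` gives 29300 nM. Compound 2 `CC1CCN(c2ccc(Nc3ncc4c(n3)N(C3CCCC3)CC(=O)N4C)nc2)CC1` reaches only the limit of the assay, > 30000 nM. Compound 3 `CCN1C(=O)CN(C2CCCC2)c2nc(Nc3ccc(N4CCCCC4)cc3)ncc21` likewise reports only the limit, > 30000 nM.

From compound 1 to compound 2 the change is methyl in place of hydrogen on a saturated ring carbon. The step it made is an at least 1.0-fold higher number from compound 1 to compound 2 (0.01 log units; that floor lies within the scatter), with the limit of > 30000 nM in this assay, at which 2 of the 3 values shown sit, setting the ceiling of what could be seen. The difference between the core of compound 1 and the core of compound 3 is not broken down here. Compound 4 `CCN1C(=O)CN(C2CCCC2)c2nc(Nc3ccc(N4CCC(C)CC4)cc3)ncc21` carries the same change relative to compound 3, namely (methyl in place of hydrogen on a saturated ring carbon), at the same place. Compound 3 already sits at the limit, so the earlier step gives no reason to expect a stronger inhibitor. For compound 4 the expected step is a step that the limit leaves unreadable from compound 3 to compound 4. Compound 4 is therefore estimated at 40000 nM. Its expected range runs for compound 4 from 15000 nM to 120000 nM.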

Compound 4, half-maximal inhibitory concentration: > 30000 nM
Compound 4: no number, only a limit; the forecaster's own chance of this, stated with the estimate: 75%; the middle value is on the limit's open side.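

No step can be read between compound 3 and compound 4, because both stop at a limit, not a number: the limit of > 30000 nM in this assay, at which 3 of the 4 values shown sit.

As far as these compounds go, how far compound 3 and compound 4 lie past that limit stays open, and with it whether 4-methylpiperidin-1-yl in place of piperidin-1-yl changes inhibition at all.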